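The compounds below may be only part of what the source reports. "The series", "measured", "known", "first", "only" and "open" are said of these compounds alone.

Measured so far:
compound 1 `CC(C)COc1cccc(C(=O)Nc2cccc(C(=O)O)c2)c1`: 1130 nM
compound 2 `O=C(O)c1cccc(NC(=O)c2ccc(-c3ccccc3)cc2)c1`: > 10000 nM

Going by the values given here, in an assay on isolated protein for agonist activity at Bile acid receptor (Homo sapiens), read by TR-FRET, with a stated time of 3 h, in the absence of a further agent (a higher number here means that more compound is needed for the effect, a lower number that less compound is needed), compound 1 gives 1130 nM, the only number in this set. Compound 2 gives > 10000 nM in this assay, which is a limit of the assay and not a number. That limit is the limit of > 10000 nM in this assay, at which 1 of the 2 values shown sits. Among the compounds with values here, no pair of measured compounds differs in one place, so no measured step exists; the two values show only that compound 1 has a number where compound 2 has none.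

Compound 3 `Cc1ccccc1-c1cccc(C(=O)Nc2cccc(C(=O)O)c2)c1` differs from compound 1 by 2-methylphenyl in place of isobutoxy on an aromatic carbon. Compound 2 differs from compound 1 in more than one place and sits at the limit, so it gives no guide to this single change. The expected step, toward less potency and at or a little beyond the usual scatter, is a 2.2-fold higher number from compound 1 to compound 3 (0.34 log units; beyond the scatter). Compound 3 is estimated at 2500 nM in this assay, with a range from 600 nM to 10000 nM.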

Compound 3, half-maximal effective concentration: 68 nM
The estimate for compound 3 lay 37-fold (1.57 log units) above the measured number; the whole stated range lies above it.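

In this assay, the aromatic carbon meta to a large group accepts a six-membered aromatic ring as well as an open chain: 2-methylphenyl in place of isobutoxy gives a 17-fold lower number from compound 1 to compound 3 (1.22 log units; beyond the scatter) at this place. The hydrogen-bond acceptor that isobutoxy carries is therefore not required for a low number here, and the larger group with no acceptor reads better in this single change. No measurement shown here gives a cause for this step.

The compounds shown do not separate the ring from its methyl, so a plain phenyl, a 2-chlorophenyl or a pyridine ring at this place would be needed to tell the two apart. Going by these compounds, whether a longer alkoxy chain or an amine on the same carbon would come close to compound 3 also remains open.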